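Epimer of a Glycosylated Lactam in a Nitric Oxide Assay

This account rests on a few compounds, and the source may have more. Where it says the series, first, only, none or still open, it means among the compounds named here.

Two glycosides have been measured in a functional assay on RAW264.7 cells (Mus musculus) for inhibition, read by Griess assay, with a stated time of 24 h; on this read-out lower numbers stand for stronger inhibition and higher numbers for weaker inhibition. Compound 1 `C[C@@H]1O[C@@H](O[C@@H]2COC(=O)C2)[C@H](O)[C@H](O)[C@H]1O` gives 60700 nM in this assay. Compound 2 `O=C1C[C@H](O[C@H]2O[C@H](CO)[C@@H](O)[C@H](O)[C@H]2O)CN1` gives 80900 nM in this assay, the higher of the two numbers, with compound 1 as its nearest neighbour at a gap that lies within the scatter. Compound 3 `O=C1C[C@H](O[C@H]2O[C@H](CO)[C@@H](O)[C@H](O)[C@@H]2O)CN1` has not yet been measured in this assay. It is related to compound 2 in this way: the two compounds have the same atoms and bonds and differ only in configuration as drawn: 1 of 6 stereo elements differ; a stereocentre at a saturated ring carbon is drawn R in compound 2 and S in compound 3. For the measured compounds named here, no step between measured compounds is available to anchor such a change, so the expectation rests on compound 2 alone. Because compound 2 gives 80900 nM and the two compounds differ only in configuration as drawn at one stereocentre, the expected step is a 1.0-fold lower number from compound 2 to compound 3 (0.00 log units; within the scatter), which is no larger than the scatter in either direction. Compound 3 is therefore estimated at 80000 nM in this assay, with a range from 30000 nM to 200000 nM.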

Compound 3, half-maximal inhibitory concentration: 67100 nM
Estimate against measurement, compound 3: 1.2-fold (0.08 log units) above; the measured number falls inside the stated range.
By their numbers in this assay, from the lowest: compounds 1, 3 and 2 (each within the scatter of the next).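

For the compounds shown here, for the first time, two measured compounds differ in one place, and in this assay that place gives a 1.2-fold lower number from compound 2 to compound 3 (0.08 log units; within the scatter). At this saturated ring carbon, then, the R and S drawings cannot be told apart by this read-out, and the stereocentre shows no measurable dependence on configuration within the scatter. The comparison is clean in one respect, and the pair offers no other structural difference to weigh: the fact that compounds 2 and 3 differ only in the configuration as drawn

The compounds shown leave open whether a different group at this stereocentre, such as an amine or a methoxy group, would give a step beyond the scatter. They also leave open whether inverting any of the other stereocentres would matter, and the pair gives no reason for the absence of a clear step here.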